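From an Ester Chain to a Hydroxy Alkene Chain

The compounds below may be only part of what the source reports. "The series", "measured", "known", "first", "only" and "open" are said of these compounds alone.

Compound 1 (`Cc1cn([C@@H]2O[C@H](CO[Si](C)(C)C(C)(C)C)[C@@]3(OS(=O)(=O)C=C3N)[C@H]2O[Si](C)(C)C(C)(C)C)c(=O)n(CC(N)=O)c1=O`): 13300 nM
Compound 2 (`CNC(=O)Cn1c(=O)c(C)cn([C@@H]2O[C@H](CO[Si](C)(C)C(C)(C)C)[C@@]3(OS(=O)(=O)C=C3N)[C@H]2O[Si](C)(C)C(C)(C)C)c1=O`): >= 250000 nM (a limit of the assay, not a number)
Compound 3 (`CCOC(=O)CCCCCn1c(=O)c(C)cn([C@@H]2O[C@H](CO[Si](C)(C)C(C)(C)C)[C@@]3(OS(=O)(=O)C=C3N)[C@H]2O[Si](C)(C)C(C)(C)C)c1=O`): 40600 nM

All three results come from a functional assay on CCRF-CEM cells (Homo sapiens) (on this read-out higher numbers stand for lower toxicity in this test and lower numbers for higher toxicity in this test), and share one core. Of the two true numbers, compound 3 holds the higher one (a 3.1-fold higher number from compound 1 to compound 3 (0.48 log units; beyond the scatter)), and the entry for compound 2 is a limit.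

Compound 4 (`Cc1cn([C@@H]2O[C@H](CO[Si](C)(C)C(C)(C)C)[C@@]3(OS(=O)(=O)C=C3N)[C@H]2O[Si](C)(C)C(C)(C)C)c(=O)n(C/C=C/CO)c1=O`) keeps that core and changes only the chain (3-hydroxyprop-1-en-1-yl in place of 4-(ethoxycarbonyl)butyl on a saturated chain carbon bound to an aromatic nitrogen): 3-hydroxyprop-1-en-1-yl in place of 4-(ethoxycarbonyl)butyl on a saturated chain carbon bound to an aromatic nitrogen.

Among the measured compounds shown here, three measured steps bear on this part of the molecule. Replacing carbamoyl with 4-(ethoxycarbonyl)butyl was a modest move (a 3.1-fold higher number from compound 1 to compound 3 (0.48 log units; beyond the scatter)), the same chain set against methylcarbamoyl gave an at least modest one (an at least 6.1-fold lower number from compound 2 to compound 3 (0.78 log units; beyond the scatter)), and the large step (an at least 18-fold higher number from compound 1 to compound 2 (1.27 log units; beyond the scatter)) ends at a limit. As far as these compounds go, none of them brings in a 3-hydroxyprop-1-en-1-yl chain, so the direction stays open. With compound 1 (13300 nM) and compound 3 (40600 nM) as the nearest guides, a result in their neighbourhood seems likely. The expected step is small (a 1.4-fold lower number from compound 3 to compound 4 (0.13 log units; within the scatter)) and probably stays within the scatter of this assay, with a slight lean towards a lower number. Compound 4 is estimated at 30000 nM and expected to fall between 10000 nM and 120000 nM in most repeats.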

Compound 4, half-maximal cytotoxic concentration: 4410 nM
Compound 4: middle estimate off by 6.8-fold (0.83 log units), on the high side; measured number below the stated range.
By their numbers in this assay, from the lowest: compound 4; then compound 1; then compound 3. At a limit, above all of these: compound 2.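

In this assay, the 3-hydroxyprop-1-en-1-yl chain in place of 4-(ethoxycarbonyl)butyl gives a 9.2-fold lower number from compound 3 to compound 4 (0.96 log units; beyond the scatter), which shows that a change on this saturated chain carbon bound to an aromatic nitrogen can move the read-out towards higher toxicity in this test by a clear margin. Among the compounds shown here, the same chain also passes the carbamoyl compound, which had the lowest number so far, with a 3.0-fold lower number from compound 1 to compound 4 (0.48 log units; beyond the scatter), so compound 4 now holds the lowest number of the series and an amide on the chain is not needed to reach it. The step of an at least 56-fold lower number from compound 2 to compound 4 (1.75 log units; beyond the scatter) starts from a value that is a limit of the assay and not a number: the limit of >= 250000 nM in this assay, at which 1 of the 4 values shown sits.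

Compound 4 differs from compound 3 in both chain length and end group, so the compounds shown cannot tell which of the two drives the step. A saturated 4-hydroxybutyl chain, or the longer chain of compound 3 ending in a hydroxy group or a carboxylic acid, would separate these two changes, and an amine at the chain end remains an open question as well.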